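Glycoside series on MCF7: stereochemical variant of compound 1

A few compounds are considered here, and "the series" means these few. Any claim that something is new, unique, unknown or untested is made for them only; others in the source may bear on it.

Three glycosylated members of this series have been run in a functional assay on MCF7 cells (Homo sapiens) for inhibition, read by MTT assay, with a stated time of 48 h, tested at 50 ug/mL; a higher number here means a stronger effect of the compound at the concentration tested, a lower number a weaker effect. Compound 1 `CC(=O)OC[C@H]1O[C@@H](Oc2nc(-c3cccs3)cc(-c3ccc(Cl)cc3)c2C#N)[C@H](OC(C)=O)[C@@H](OC(C)=O)[C@@H]1OC(C)=O` gives 5%. Compound 2 `N#Cc1c(-c2ccc(Cl)cc2)cc(-c2cccs2)nc1O[C@@H]1O[C@H](CO)[C@@H](O)[C@H](O)[C@H]1O` gives 0%, and compound 3 `CC(=O)OC[C@H]1O[C@@H](Oc2nc(-c3cccs3)cc(-c3ccc(Cl)cc3)c2C#N)[C@H](OC(C)=O)[C@H]1OC(C)=O` gives 0%. Compound 1 holds the largest of the three figures, yet its gaps to compound 2 and to compound 3 both fall within the scatter, so the three read as indistinguishable and all near the floor of the read-out.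

Compound 4 `CC(=O)OC[C@H]1O[C@@H](Oc2nc(-c3cccs3)cc(-c3ccc(Cl)cc3)c2C#N)[C@H](OC(C)=O)[C@@H](OC(C)=O)[C@H]1OC(C)=O` is the next candidate. Against compound 1 the difference is the two compounds have the same atoms and bonds and differ only in configuration as drawn: 1 of 5 stereo elements differ; a stereocentre at a saturated ring carbon is drawn R in compound 1 and S in compound 4. Among the compounds with values here, no measured pair in this set isolates such a change, so no size can be taken from the data; with all three members close to zero inhibition, no step beyond the scatter is expected in this assay. The expected step of no change at the digits printed from compound 1 to compound 4 (within the scatter) is therefore essentially flat, and compound 4 is estimated at 5%, with a range from 0% to 15%.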

Compound 4, a percentage reported as inhibition, at one concentration (the size of the read-out at that concentration, not a potency): 5%
Beside the measured number, compound 4's estimate shows no gap at the digits printed, within the range that was stated.
By their numbers in this assay, from the lowest: compounds 2, 3, 1 and 4 (each within the scatter of the next).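

Inverting one saturated ring carbon from R to S is the first change of configuration read in this series, and in this assay it gives no change at the digits printed from compound 1 to compound 4 (within the scatter). The pair isolates configuration alone: the fact that compounds 1 and 4 differ only in the configuration as drawn. At this saturated ring carbon, neither drawn configuration lifts the read-out off the floor at the concentration tested.

On these data alone, whether this configuration matters on a more active member of the series stays open, as a flat step near the floor cannot settle it. Also open, as far as these compounds go, is what an amine at this saturated ring carbon would give.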